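The compounds below may be only part of what the source reports. "The series", "measured", "known", "first", "only" and "open" are said of these compounds alone.

Working notes on the series.

Compound 1 `O=C1OC[C@H](Cc2ccccc2)[C@H]1Cc1cccc(C(F)(F)F)c1` and compound 3 `O=C1OC[C@H](Cc2ccccc2)[C@H]1Cc1ccc(C(F)(F)F)cc1` are built from the same atoms joined differently; the difference between the two cores is not broken down here. In a functional assay on HL-60 cells (Homo sapiens) for cytotoxicity, read by WST assay, with a stated time of 48 h (on this read-out lower numbers stand for an effect already at smaller amounts and higher numbers for an effect only at larger amounts of compound), compound 1 gives 34000 nM, and in this assay compound 3 gives 22000 nM, the two values lying within the scatter of each other.

Compound 2 `O=C1OC[C@H](Cc2ccccc2)[C@H]1Cc1cccc(F)c1` differs from compound 1 by fluoro in place of trifluoromethyl on an aromatic carbon. This change made a step of a 2.2-fold higher number from compound 1 to compound 2 (0.34 log units; beyond the scatter), and in this assay compound 2 gives 75000 nM.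

Compound 4 `O=C1OC[C@H](Cc2ccccc2)[C@H]1Cc1ccc(F)cc1` is not yet measured. It differs from compound 3 by fluoro in place of trifluoromethyl on an aromatic carbon. Among the measured compounds shown here, this is the same kind of change as the one from compound 1 to compound 2, but not the same change: in compound 1 the departing group sits meta to a large group, in compound 3 it sits para to a large group. For the measured compounds named here, nothing measured so far separates the part played by this difference in place from the part played by the groups exchanged, so the one measured step of this kind is the only guide.

On that basis a step of about a 2.0-fold higher number from compound 3 to compound 4 (0.31 log units; beyond the scatter) in this assay is expected, roughly the size seen earlier. That expectation rests on the step of a 2.2-fold higher number from compound 1 to compound 2 (0.34 log units; beyond the scatter) applied to compound 3 at 22000 nM. Compound 4 is therefore estimated at 45000 nM in this assay, with a likely range from 24000 nM to 90000 nM.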

Compound 4, half-maximal effective concentration: 57000 nM
The estimate for compound 4 lay 1.3-fold (0.10 log units) below the measured number; measured number inside the range.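

In this assay, fluoro in place of trifluoromethyl on an aromatic carbon gave a 2.6-fold higher number from compound 3 to compound 4 (0.41 log units; beyond the scatter), and the size of this step carried over from the core of compound 1 to the core of compound 3, with no difference beyond the scatter: the same change on two cores in this assay, a 2.2-fold higher number (0.34 log units; beyond the scatter) from compound 1 to compound 2 and a 2.6-fold higher number (0.41 log units; beyond the scatter) from compound 3 to compound 4, 1.2-fold (0.07 log units) apart, within the scatter of two such steps. The exchange of 3-fluorophenyl for 4-fluorophenyl gave a 1.3-fold lower number from compound 2 to compound 4 (0.12 log units; within the scatter), so this pair of fluoro compounds cannot be told apart on this read-out. Among the compounds shown here, the agreement rests on only two pairs of closely related compounds in a single assay, so it supports carrying the change between these two cores but does not show that it would hold on a more different core, and it gives no reason for the size of the step.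

The compounds shown leave open how other groups in the same place would compare with fluoro and trifluoromethyl, for example chloro, methoxy, a nitrile, an amine or a carboxylic acid. Also open, from the compounds shown here alone, is whether the step would keep its size with a change on the other aromatic ring, which is the same unsubstituted phenyl in all four compounds.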